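Diethylamino replaces dipropylamino on the shared core

The source may report more compounds than this note shows. Statements on the series, on what has been measured and on what is new or still open speak of the compounds shown alone.

Compound 1 `CCCN(CCC)Cc1ccc(Cl)c(-c2ccccc2OC)c1` stands apart from the other measured members of the series: in a functional assay on HEK293 cells for agonist activity at 5-hydroxytryptamine receptor 7 (Homo sapiens), read by cAMP accumulation, with a stated time of 30 min (on this read-out higher numbers stand for an effect only at larger amounts of compound and lower numbers for an effect already at smaller amounts), compound 1 is recorded as "not active" (no number reported), with further entries that also give no single number. The two measured comparators carry other amines on the same core. Compound 2 `COc1ccccc1-c1cc(C2CCN(C)C2)ccc1Cl` gives in this assay 562 nM; 560 nM (2 entries), and its repeat entries agree within the usual scatter (the several entries of compound 2 in this assay, 562 nM; 560 nM (2 entries)). Compound 3 `CCNCc1ccc(Cl)c(-c2ccccc2OC)c1` gives in this assay 759 nM; 770 nM (2 entries), again with close repeats (the several entries of compound 3 in this assay, 759 nM; 770 nM (2 entries)). Going by the values given here, no step between measured compounds that differ in one place is available, so the change from compound 1 to compound 4 `CCN(CC)Cc1ccc(Cl)c(-c2ccccc2OC)c1` is judged on its own: diethylamino in place of dipropylamino on a saturated chain carbon bound to an aromatic carbon. Compound 1 with no measurable effect and compound 3 with a clear number bracket the amine variation seen so far. For compound 4 the step in this assay is expected to run toward activity, from no recorded effect to a number, though most likely weaker than compound 3 at 759 nM; 770 nM (2 entries) and with a real chance of no number again. Compound 4 is therefore estimated at 2500 nM in this assay, within the range 600 nM to 10000 nM.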

Compound 4, half-maximal effective concentration: "not active" (no number reported)
No number was reported for compound 4; there is nothing to compare the estimate with.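

In this assay, going by these compounds alone, compound 1 gives "not active" (no number reported) and compound 4 gives "not active" (no number reported), so no step between them can be read. The compounds shown leave open whether diethylamino and dipropylamino differ at all in their effect on the shared core.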